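This account rests on a few compounds, and the source may have more. Where it says the series, first, only, none or still open, it means among the compounds named here.

For the measured compounds named here, compound 2 `CC(=O)N[C@H]1CCN(c2cccc3oc(CCCCc4ccccc4)cc23)C1` is one of two compounds measured in an assay on NIH3T3 cells for binding affinity to melatonin receptor type 1A (Homo sapiens); on this read-out lower numbers stand for stronger inhibition and higher numbers for weaker inhibition. In this assay compound 2 gives 22 nM, the higher of the two numbers. The other, compound 1 `CC(C)C(=O)NCCCc1cccc2oc(CCCCc3ccccc3)cc12`, gives 3.7 nM in this assay. Going by the values given here, the single measured step runs a 5.9-fold higher number from compound 1 to compound 2 (0.77 log units; beyond the scatter), and it swaps the whole side group, not only the part sitting on the carbonyl, so it cannot be split into a share for each part.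

Compound 3 `CC(C)C(=O)N[C@H]1CCN(c2cccc3oc(CCCCc4ccccc4)cc23)C1` has not yet been measured. It differs from compound 2 by isopropyl in place of methyl on a carbonyl carbon. Among the compounds with values here, compound 1 already carries an isopropyl on its carbonyl, but on a different side group, so no measured step isolates this one change, and the step of a 5.9-fold higher number from compound 1 to compound 2 (0.77 log units; beyond the scatter) is the only scale at hand. The expectation for this assay is therefore a small step, a 1.6-fold lower number from compound 2 to compound 3 (0.20 log units; within the scatter), leaning if anything toward a lower number and quite possibly within the scatter. Compound 3 is thus estimated at 14 nM in this assay, with a range from 5 nM to 45 nM.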

Compound 3, inhibition constant: 105 nM
For compound 3 the middle estimate is 7.5-fold (0.88 log units) below the measured one; the whole stated range lies below it.
By their numbers in this assay, from the lowest: compound 1; then compound 2; then compound 3.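

In this assay, putting isopropyl in place of methyl on the carbonyl carbon gives a 4.8-fold higher number from compound 2 to compound 3 (0.68 log units; beyond the scatter) and so moves the number beyond the scatter. For the compounds shown here, this is the first measured step that isolates the group on the carbonyl, and it shows that this part of the 3-acetamidopyrrolidin-1-yl side group is sensitive to a change of only a few carbons, with no hydrogen-bond donor or acceptor entering or leaving. An isopropyl on a carbonyl does not always come with a high number, since compound 1, which carries the same (isopropylcarbonyl)amino end on a different side group, gives 3.7 nM while compound 3 gives 105 nM in the same assay.

The compounds shown leave open how the number changes with groups of intermediate or different shape on this carbonyl carbon, such as ethyl or cyclopropyl. They also leave open whether the same change from methyl to isopropyl would have a similar effect on the side group of compound 1, as no acetamide with that side group is among them. No measurement given here explains why the number rises at this position.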